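A Urea for an Amide at the Carbonyl of Compound 1

The compounds below may be only part of what the source reports. "The series", "measured", "known", "first", "only" and "open" are said of these compounds alone.

Compound 1 `COc1cc(-c2nn(-c3cccc(NC(=O)c4cccc(C(F)(F)F)c4)c3)cc2-c2ccncc2)ccc1Cl`: 1560 nM
Compound 2 `O=C(Nc1cccc(-n2cc(-c3ccncc3)c(-c3ccc(Cl)c(O)c3)n2)c1)Nc1cc(C(F)(F)F)cc(C(F)(F)F)c1`: 1250 nM
Compound 3 `O=C(Nc1cccc(-n2cc(-c3ccncc3)c(-c3ccc(Cl)c(O)c3)n2)c1)Nc1ccc(Cl)c(C(F)(F)F)c1`: 798 nM

Of the compounds shown here, three have been measured in a functional assay on SK-MEL-2 cells (Homo sapiens) for inhibition, read by sulforhodamine B assay, with a stated time of 48 h; on this read-out lower numbers stand for stronger inhibition of growth and higher numbers for weaker inhibition of growth. Compound 1 gives 1560 nM in this assay, compound 2 gives 1250 nM and compound 3 gives 798 nM. On these numbers compound 1 does not separate from either of the other two: its gap to compound 2 and its gap to compound 3 both lie within the usual scatter of repeated measurements, so no ranking among the three can be drawn from them.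

Compound 4 `COc1cc(-c2nn(-c3cccc(NC(=O)Nc4ccc(Cl)c(Cl)c4)c3)cc2-c2ccncc2)ccc1Cl` has not yet been measured. It differs from compound 1 in one place: (3,4-dichlorophenyl)amino in place of 3-(trifluoromethyl)phenyl on a carbonyl carbon. The carbonyl that carried the 3-(trifluoromethyl)phenyl now carries a (3,4-dichlorophenyl)amino group, so the linkage to the outer ring changes from (3-(trifluoromethyl)phenyl)carbonyl to (3,4-dichlorophenyl)carbamoyl. Among the compounds with values here, no measured pair shows this change on its own, so its size is unknown here. Since compound 2 and compound 3 sit within the scatter of compound 1, a small step or none beyond the scatter is expected for a 1.6-fold lower number from compound 1 to compound 4 (0.22 log units; within the scatter). Compound 4 is therefore estimated at 950 nM in this assay, with a range from 350 nM to 2500 nM.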

Compound 4, concentration for 50% growth inhibition: 1140 nM
Estimate against measurement, compound 4: 1.2-fold (0.08 log units) below; measured number inside the range.
By their numbers in this assay, from the lowest: compounds 3, 4, 2 and 1 (each within the scatter of the next).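

In this assay, within the data shown here, the step of a 1.4-fold lower number from compound 1 to compound 4 (0.14 log units; within the scatter) gives the first direct comparison at this carbonyl carbon, and it shows that (3,4-dichlorophenyl)amino can stand in place of 3-(trifluoromethyl)phenyl without a difference that can be told from the scatter. The swap is not a trivial one on paper: the amide linkage becomes a urea, and the entering group brings a nitrogen and a hydrogen-bond donor that the leaving group lacks, yet the two compounds do not separate on this read-out. No measurement available here bears on why the step stays this small.

A single step also changes the linkage and the groups on the outer ring together, so the share of each cannot be read from it, and the urea and the amide are not compared with the same outer ring. The compounds shown also leave open whether a sulfonamide in place of the carbonyl linkage, or a carboxylic acid on the outer ring, would stay within the scatter of compound 1 as well.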